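Amino in Place of Bromo on the Phenyl Ring

The source may hold more compounds than are shown below. What is called first, only, known or untested is meant among the compounds shown, and "the series" means these compounds.

Compound 1 `Fc1cccc(-c2nc(Nc3ccccc3)c3cc(F)ccc3n2)c1` is the parent of this small set. In a functional assay on COLO 205 cells (Homo sapiens) for cytotoxicity, read by MTT assay, with a stated time of 48 h (a lower number here means a stronger inhibitor, a higher number a weaker inhibitor), compound 1 gives 49700 nM. Compound 2 `Fc1cccc(-c2nc(Nc3cccc(Br)c3)c3cc(F)ccc3n2)c1` carries a bromo on an aromatic carbon in place of a hydrogen. In this assay compound 2 gives > 50000 nM, which is a limit of the assay. Compound 3 `Fc1cccc(-c2nc(Nc3ccccc3Br)c3cc(F)ccc3n2)c1` carries the bromo at another place on the same ring. In this assay compound 3 gives > 50000 nM, again a limit of the assay. The steps of a number no lower from compound 1 to compound 2 (the limit leaves the size open) and a number no lower from compound 1 to compound 3 (the limit leaves the size open) cannot be sized, and a step that the two limits leave unreadable from compound 2 to compound 3 is equally unreadable owing to the limit of > 50000 nM in this assay, at which 2 of the 3 values shown sit. Compound 3 thus sits at the upper boundary of what this assay can report. Compound 4 `Nc1ccccc1Nc1nc(-c2cccc(F)c2)nc2ccc(F)cc12` differs from compound 3 by amino in place of bromo on an aromatic carbon. Among the measured compounds shown here, none of the measured steps involves an amino group, so no step bears directly on this change. For the measured compounds named here, with compound 1 at 49700 nM as the only number, compound 4 is expected to remain a weak inhibitor, with an estimated 40000 nM spanning 10000 nM to 150000 nM. The step of an at least 1.2-fold lower number from compound 3 to compound 4 (0.09 log units; that floor lies within the scatter) is the expected one, and the result may well end as another limit.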

Compound 4, half-maximal inhibitory concentration: > 50000 nM
Compound 4 ended at the assay's limit; the forecaster's own chance of this, stated with the estimate: 55%; at least 1.2-fold (0.09 log units) between middle value and limit.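

In this assay compound 4 gives > 50000 nM, which is a limit of the assay, so amino on this aromatic carbon, ortho to a large group, yields no readable number, just as bromo did in compound 3. The data show a number no lower from compound 1 to compound 4 (the limit leaves the size open). A second kind of group at this place, one that brings a hydrogen-bond donor where bromo had none, thus still does not give a reading within the range of the assay. The size of that step cannot be read, nor can the steps joining compound 4 to compound 2 and compound 3, and they share one limit: the limit of > 50000 nM in this assay, at which 3 of the 4 values shown sit.

From the compounds shown here alone, whether a hydroxyl, a methoxy or a carboxylic acid at this place would give an actual number remains open. Going by these compounds, whether amino and bromo differ here at all also stays open.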